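The source may report more compounds than this note shows. Statements on the series, on what has been measured and on what is new or still open speak of the compounds shown alone.

Measured compounds in a functional assay (aorta) with Rattus norvegicus as the target; a higher number here means a more potent compound, by a factor of ten per unit of this negative logarithm, a lower number a less potent compound:
compound 1 `CC1(C)C=C(n2ccccc2=O)c2cc(C(=O)c3cccs3)ccc2O1`, 6.4
compound 2 `CC1(C)C=C(n2ccccc2=O)c2cc(C(=O)c3ccco3)ccc2O1`, 6.49
compound 3 `CC1(C)C=C(n2ccccc2=O)c2cc(C(=O)c3ccc([N+](=O)[O-])cc3)ccc2O1`, 6.2

Across these three, compound 3 holds the lowest of the three numbers, yet neither gap is more than scatter: a number 0.20 log units lower from compound 1 to compound 3 (within the scatter) and a number 0.29 log units lower from compound 2 to compound 3 (within the scatter). The remaining pair is likewise flat, a number 0.09 log units higher from compound 1 to compound 2 (within the scatter). Every measured step exchanges the whole group on the carbonyl carbon, and none of them moves this assay beyond its scatter.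

Compound 4 `CC1(C)C=C(n2ccccc2=O)c2cc(C(=O)c3ccccc3[N+](=O)[O-])ccc2O1` is the next case. Against compound 3 the change is 2-nitrophenyl in place of 4-nitrophenyl on a carbonyl carbon. Within the data shown here, no measured step shifts the nitro group from one position of the phenyl to another, so there is no directly comparable precedent; the nearest evidence is that three quite different groups on that carbonyl carbon all gave numbers within scatter of one another. On that basis the expectation for compound 4 is a step of about a number 0.10 log units higher from compound 3 to compound 4 (within the scatter), not beyond the scatter. Compound 4 is therefore estimated at 6.3, with a range from 5.8 to 6.8.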

Compound 4, logarithm of the reciprocal of the active concentration, log(1/C): 6.17
Beside the measured number, compound 4's estimate is 0.13 log units above it; measured number inside the range.
By their numbers in this assay, from the lowest: compounds 4, 3, 1 and 2 (each within the scatter of the next, the first and the last beyond it).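

With 2-nitrophenyl in place of 4-nitrophenyl on the carbonyl carbon, this assay gives a number 0.03 log units lower from compound 3 to compound 4 (within the scatter) and so shows that, for this pair, relocating the nitro group on the phenyl leaves no readable difference. Among these compounds, the same compound gives the only step in the set that passes the scatter, a number 0.32 log units lower from compound 2 to compound 4 (beyond the scatter) and modest in size, whereas a number 0.23 log units lower from compound 1 to compound 4 (within the scatter) and compound 3 stays within the scatter of compound 2, so this single step marks no clear separation between the groups. Nothing available here accounts for these numbers.

Still open, as far as these compounds go, is whether an amine or a carboxylic acid on the phenyl would move the number beyond the narrow band seen so far. Also open, from the compounds shown here alone, is the effect of a saturated group such as cyclohexyl on the carbonyl carbon.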